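The compounds below may be only part of what the source reports. "The series", "measured", "known", "first", "only" and "open" are said of these compounds alone.

Working notes on the series. Compound 1 `CCS(=O)(=O)Nc1ccc(NC(=O)c2cccc(C(F)(F)F)c2)cc1OC` and compound 2 `CCS(=O)(=O)Nc1ccc(NC(=O)c2cc(C(F)(F)F)cc(C(F)(F)F)c2)cc1OC` share the same core and differ only in one added trifluoromethyl. In an ADME assay on HEK293 cells (Homo sapiens) for cytotoxicity, read by MTT assay, with a stated time of 48 h (a lower number here means a stronger inhibitor, a higher number a weaker inhibitor), compound 1 gives > 250000 nM, which is a limit of the assay and not a number. In this assay compound 2 gives > 250000 nM, likewise a limit. The step from compound 1 to compound 2 reads a step that the two limits leave unreadable from compound 1 to compound 2 and cannot be sized because both values sit at the limit of > 250000 nM in this assay, at which 2 of the 2 values shown sit. Compound 2 therefore stands at the limit, with no numbered value anywhere in the set to rank it against.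

Compound 3 `COc1cc(NC(=O)c2cc(C(F)(F)F)cc(C(F)(F)F)c2)ccc1NS(=O)(=O)C(F)(F)F` differs from compound 2 by trifluoromethyl in place of ethyl on a sulfonyl sulfur. For the measured compounds named here, no measured step touches the sulfonyl substituent, and the one measured step in the set is unreadable. Nothing in the measured compounds points to compound 3 falling inside the measured range, so the expectation for compound 3 is another limit reading. The estimate for compound 3 in this assay is 250000 nM, ranging from 100000 nM to 1000000 nM. The expected step from compound 2 to compound 3 is accordingly a number no higher from compound 2 to compound 3 (the limit leaves the size open).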

Compound 3, half-maximal inhibitory concentration: > 250000 nM
Compound 3: only a limit was reported; the forecaster's own chance of this, stated with the estimate: 85%; the middle value sits exactly at the limit.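

In this assay compound 3 gives > 250000 nM, a limit of the assay and not a number, so no size can be read for the step between compound 2 and compound 3: the limit of > 250000 nM in this assay, at which 3 of the 3 values shown sit.

The compounds shown leave open how far each one lies from that limit, and whether any change to the shared core gives a numbered value in this assay.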